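The source may hold more compounds than are shown below. What is called first, only, known or untested is meant among the compounds shown, and "the series" means these compounds.

Measured compounds:
- compound 1 `CC[C@H](C)C(=O)O[C@H]1C[C@@H](C)C=C2C=C[C@H](C)[C@H](CC[C@@H](O)C[C@@H](CC(=O)NO)OC(=O)c3ccccc3)[C@H]21`: 3300 nM
- compound 2 `CC[C@H](C)C(=O)O[C@H]1C[C@@H](C)C=C2C=C[C@H](C)[C@H](CC[C@@H](O)C[C@@H](CC(=O)NO)OC(=O)c3ccc([N+](=O)[O-])cc3)[C@H]21`: 8200 nM

Two compounds of the series have been run in a functional assay on PC-3 cells (Homo sapiens) for inhibition, read by sulforhodamine B assay, with a stated time of 48 h; a lower number here means a stronger inhibitor, a higher number a weaker inhibitor. Compound 1 gives 3300 nM and compound 2 gives 8200 nM. Within the data shown here, the only measured step is a 2.5-fold higher number from compound 1 to compound 2 (0.40 log units; beyond the scatter), so compound 2 stands as the higher of the two numbers, with compound 1 the nearest neighbour and a weaker number for compound 2 beyond the scatter.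

Compound 3 `CC[C@H](C)C(=O)O[C@H]1C[C@@H](C)C=C2C=C[C@H](C)[C@H](CC[C@@H](O)C[C@@H](CC(=O)NO)OC(=O)c3ccc(Cl)cc3)[C@H]21` is not yet measured. It differs from compound 2 by chloro in place of nitro on an aromatic carbon. Among the measured compounds shown here, the one measured step bears on it only indirectly: a 2.5-fold higher number from compound 1 to compound 2 (0.40 log units; beyond the scatter) shows that putting the nitro onto the ring raised the number by a modest amount, and compound 3 removes that nitro again while putting a chloro in its place. For the measured compounds named here, no measured pair shows a chloro on this ring, so the expectation rests on the removal of the nitro alone. The expected step is a 1.8-fold lower number from compound 2 to compound 3 (0.26 log units; within the scatter), pointing back toward the number of compound 1, but with room for it to fall anywhere within the scatter of either compound. Compound 3 is therefore estimated at 4500 nM in this assay, with a range from 2000 nM to 10000 nM.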

Compound 3, half-maximal inhibitory concentration: 21700 nM
Compound 3: the middle estimate sits 4.8-fold (0.68 log units) below what was measured; measured number outside the range, above it.
By their numbers in this assay, from the lowest: compound 1; then compound 2; then compound 3.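

In this assay, the carbon para to a large group on the benzoyl ring now carries two different groups, and neither improves on hydrogen: chloro in place of hydrogen gives a 6.6-fold higher number from compound 1 to compound 3 (0.82 log units; beyond the scatter), which is larger than the step seen with nitro. Exchanging nitro for chloro does not return the number toward that of the unsubstituted ring but moves it further away, with a 2.6-fold higher number from compound 2 to compound 3 (0.42 log units; beyond the scatter), so compound 1 is the strongest inhibitor of the three and compound 3 the weakest. Nothing available explains why chloro gives a higher number than nitro at this position.

Among the three compounds, hydrogen is the best of the groups at this carbon, but it remains open whether any substituent there can match or beat it, for example fluoro, methoxy, an amine or a carboxylic acid. As far as these compounds go, it is also open whether chloro or nitro on another carbon of the ring would give the same order, and whether that order would hold in a cell line other than the one in this assay.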